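A Repeated Ester Change, Now on a Second Core

The source may hold more compounds than are shown below. What is called first, only, known or untested is meant among the compounds shown, and "the series" means these compounds.

All numbers here come from a functional assay on NIH3T3 cells (Mus musculus) for inhibition, read by MTT assay, with a stated time of 72 h; a lower number here means a stronger inhibitor, a higher number a weaker inhibitor. Compound 1 `C=C1CC[C@H]2[C@@](C)(CC[C@@H](O)[C@@]2(C)C(=O)OC)[C@@H]1CCC1=CCOC1=O` gives 60600 nM. Compound 2 `C=C1CC[C@H]2[C@@](C)(CC[C@@H](O)[C@@]2(C)C(=O)OCc2ccccc2)[C@@H]1CCC1=CCOC1=O` shares its core and differs from it by phenyl in place of hydrogen on a saturated chain carbon bound to an oxygen next to a carbonyl group; in this assay compound 2 gives 37900 nM, and the step of a 1.6-fold lower number from compound 1 to compound 2 (0.20 log units; within the scatter). Compound 3 `C=C1CC[C@H]2[C@@](C)(CC[C@@H](OC(C)=O)[C@@]2(C)C(=O)OC)[C@@H]1/C=C/C1=CCOC1=O` rests on a different core; the difference between the two cores is not broken down here. In this assay compound 3 gives 32300 nM, which sits close to the other two values. Compound 4 `C=C1CC[C@H]2[C@@](C)(CC[C@@H](OC(C)=O)[C@@]2(C)C(=O)OCc2ccccc2)[C@@H]1/C=C/C1=CCOC1=O` is derived from compound 3 by phenyl in place of hydrogen on a saturated chain carbon bound to an oxygen next to a carbonyl group, the same change already seen between compound 1 and compound 2, at a place described in the same words. Because the earlier step of a 1.6-fold lower number from compound 1 to compound 2 (0.20 log units; within the scatter) stayed within the scatter, the same change on the core of compound 3 is expected to move the number little as well. Compound 4 is therefore estimated at about 22000 nM, with a likely range from 10000 nM to 50000 nM. This estimate corresponds to an expected step of a 1.5-fold lower number from compound 3 to compound 4 (0.17 log units; within the scatter).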

Compound 4, half-maximal inhibitory concentration: 52700 nM
Beside the measured number, compound 4's estimate is 2.4-fold (0.38 log units) below it; the whole stated range lies below it.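

In this assay, replacing methoxycarbonyl with benzyloxycarbonyl on the second core gives a 1.6-fold higher number from compound 3 to compound 4 (0.21 log units; within the scatter), so here too the change stays within what repeated measurements would show. Set beside the same change on the first core, the two steps cannot be told apart: the same change on two cores in this assay, a 1.6-fold lower number (0.20 log units; within the scatter) from compound 1 to compound 2 and a 1.6-fold higher number (0.21 log units; within the scatter) from compound 3 to compound 4, 2.6-fold (0.42 log units) apart, within the scatter of two such steps. This shows that in these two pairs of compounds the change carries from one core to the other as a step too small to read, but it does not show that the change has no effect at all, and the printed directions of the two steps should not be taken as a real reversal.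

The compounds shown leave open whether a carboxylic acid or an amide in place of the methoxycarbonyl group, or an ester with a longer chain, would move the number beyond the scatter. They also leave open whether any such group would behave alike on both cores.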